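This account rests on a few compounds, and the source may have more. Where it says the series, first, only, none or still open, it means among the compounds named here.

Of the compounds shown here, three of a shared core have been measured in an assay on HEK293 cells for agonist activity at transient receptor potential cation channel subfamily M member 8 (Homo sapiens), read by fluorescence and calcium flux, with a stated time of 15 min; on this read-out higher numbers stand for an effect only at larger amounts of compound and lower numbers for an effect already at smaller amounts. Compound 1, `CCN(Cc1cccs1)C(=O)C(C)Oc1ccc(C)cc1`, gives 889 nM. Compound 2, `CCN(Cc1cccs1)C(=O)COc1ccc(C(C)C)cc1`, gives 397 nM. Compound 3, `Cc1ccc(OCC(=O)N(Cc2cccs2)c2ncccn2)cc1`, gives 3700 nM. On these numbers compound 2 stands lowest: its nearest neighbour is compound 1, beyond the scatter, and compound 3 lies furthest from it, also beyond the scatter.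

Compound 4, `CCN(Cc1cccs1)C(=O)COc1ccc(Cl)cc1`, has not yet been measured. It differs from compound 2 as follows: chloro in place of isopropyl on an aromatic carbon. For the measured compounds named here, no step between measured compounds isolates this change, so the expectation rests on the spread among compounds 1, 2 and 3, which all sit within the same order of magnitude. The step from compound 2 to compound 4 is expected to be modest, a 2.0-fold higher number from compound 2 to compound 4 (0.30 log units; within the scatter), most likely towards a somewhat higher number in this assay . Compound 4 is therefore estimated at 800 nM in this assay , with a range from 250 nM to 2500 nM.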

Compound 4, half-maximal effective concentration: 39 nM
Compound 4: the middle estimate sits 21-fold (1.31 log units) above what was measured; measured number outside the range, below it.
By their numbers in this assay, from the lowest: compound 4; then compound 2; then compound 1; then compound 3.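

Swapping isopropyl for chloro on an aromatic carbon, para to a large group, gives a 10-fold lower number from compound 2 to compound 4 (1.01 log units; beyond the scatter) in this assay, which shows that the number in this assay depends strongly on what sits at this position. Compounds 1, 2 and 3 differ from one another in more than one place, so none of their comparisons could isolate this position or reveal a step of this size. Nothing shown here explains why this exchange of 3 carbon atoms for 1 chlorine atom has so large an effect.

On these data alone, it remains open whether the lower number is specific to chloro or would also appear with fluoro, bromo, methoxy or trifluoromethyl at the same place. As far as these compounds go, it is also open whether the same exchange would give a similar step on the other variants of the shared core, such as that of compound 1 or compound 3.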